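From 4-chlorophenyl to 3-chlorophenyl on the shared ester

This account rests on a few compounds, and the source may have more. Where it says the series, first, only, none or still open, it means among the compounds named here.

Three esters of one core have been measured in a functional assay on SK-LU-1 cells (Homo sapiens) for antiproliferative activity, read by sulforhodamine B assay, with a stated time of 48 h, tested at 50 uM; a lower number here means less inhibition, a higher number more inhibition at the concentration tested (going by the name of the read-out). Compound 1 `COc1cccc(C(=O)Oc2cc3c(cc2C)[C@@H](C(C)C)CC=C3C)c1` gives 24.2%. Compound 2 `CC1=CC[C@H](C(C)C)c2cc(C)c(OC(=O)c3ccc(Cl)cc3)cc21` gives 17.4%. Compound 3 `COc1ccc(C(=O)Oc2cc3c(C)ccc(C(C)C)c3cc2C)cc1`, whose core differs from the other two, gives 32.8%. Compound 2 thus stands at the lowest of the three numbers, but its gap to compound 1 lies within the scatter, and only the gap to compound 3 lies beyond it.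

The unmeasured compound 4 `CC1=CC[C@H](C(C)C)c2cc(C)c(OC(=O)c3cccc(Cl)c3)cc21` differs from compound 2 in one place: 3-chlorophenyl in place of 4-chlorophenyl on a carbonyl carbon. The same atoms are joined differently, so nothing leaves or enters the molecule as a whole.

Within the data shown here, only one measured step touches the aryl group on this carbonyl carbon: a number 6.8 percentage points lower from compound 1 to compound 2 (within the scatter). That exchange of a whole substituent pattern produced no change beyond the scatter. Among the measured compounds shown here, no measured pair shows a chlorine shifted on the ring, so the expectation rests on that single step alone, and a step of no more than the scatter is expected in this assay, with no clear direction.

Compound 4 is therefore expected to give about 22% (range 10% to 36%), an expected step of a number 4.6 percentage points higher from compound 2 to compound 4 (within the scatter).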

Compound 4, a percentage reported as inhibition, at one concentration (the size of the read-out at that concentration, not a potency): 30.6%
Beside the measured number, compound 4's estimate is 8.6 percentage points below it; measured number inside the range.
By their numbers in this assay, from the lowest: compounds 2, 1, 4 and 3 (each within the scatter of the next, the first and the last beyond it).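

In this assay, among these compounds, the aryl group on this carbonyl carbon proves sensitive to where its chlorine sits: 3-chlorophenyl in place of 4-chlorophenyl gives a number 13.2 percentage points higher from compound 2 to compound 4 (beyond the scatter), the first step at this position that lies beyond the scatter, although the same atoms remain in the molecule. Chloro in place of methoxy on an aromatic carbon gives a number 6.4 percentage points higher from compound 1 to compound 4 (within the scatter), so among the esters of the shared core, only the shift of the chlorine produces a step beyond the scatter, and that rests on this one pair. Nothing available explains why moving the chlorine alters the inhibition at the concentration tested.

From the compounds shown here alone, compound 3 has a different core and differs from the other compounds in more than one place, so it remains open whether the shift of the chlorine would give a similar step on that core. Also open, going by these compounds, is how an amine or a carboxylic acid on this aryl ring would compare with the chlorine of compound 4 in this assay.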